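Trimming a Chlorine from a Diaryl Ether Quinazoline

A few compounds are considered here, and "the series" means these few. Any claim that something is new, unique, unknown or untested is made for them only; others in the source may bear on it.

Measured compounds:
- Compound 1, `N#Cc1ccc(Nc2nc(Oc3c(Br)cc(Br)cc3Br)c3ccccc3n2)cc1`: 58000 nM
- Compound 2, `COc1cc(C#N)cc(OC)c1Oc1nc(Nc2ccc(C#N)cc2)nc2ccccc12`: 194000 nM
- Compound 3, `N#Cc1ccc(Nc2nc(Oc3ccc(Cl)cc3Cl)c3ccccc3n2)cc1`: 32000 nM

In an ADME assay on MT4 cells (Homo sapiens) for cytotoxicity, read by MTT assay, with a stated time of 4 days (a higher number here means that more compound is tolerated, a lower number that less compound is tolerated), compound 3 carries the lowest of the three numbers. Its nearest neighbour is compound 1, reached by a 1.8-fold lower number from compound 1 to compound 3 (0.26 log units; within the scatter), a step that stays within the scatter; compound 2, which gives 194000 nM in this assay, lies beyond it. Compound 4, `N#Cc1ccc(Nc2nc(Oc3ccc(Cl)cc3)c3ccccc3n2)cc1`, has not been measured yet. It differs from compound 3 in one place: hydrogen in place of chloro on an aromatic carbon. Cut one bond further out the change reads 2,4-dichlorophenoxy to 4-chlorophenoxy. Within the data shown here, no measured pair removes a single chloro from this aryl ether, so the only step that bears on it is the exchange of the whole halogenated ring from compound 1 to compound 3, which was small. On that basis compound 4 is expected to stay close to compound 3, with a 1.3-fold higher number from compound 3 to compound 4 (0.10 log units; within the scatter) as the estimated step, and no move beyond the scatter is anticipated. Compound 4 is therefore estimated at 40000 nM in this assay, with a range from 15000 nM to 110000 nM.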

Compound 4, half-maximal cytotoxic concentration: 198000 nM
The estimate for compound 4 lay 5.0-fold (0.69 log units) below the measured number; measured number outside the range, above it.
By their numbers in this assay, from the lowest: compounds 3 and 1 (each within the scatter of the next); then compounds 2 and 4 (each within the scatter of the next).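

In this assay, among these compounds, taking away the single chloro ortho to a large group, with hydrogen entering in its place, gives a 6.2-fold higher number from compound 3 to compound 4 (0.79 log units; beyond the scatter) and so moves the number beyond the scatter, which the exchange of the whole halogenated ring between the earlier compounds did not do. The exchange of 2,4,6-tribromophenyl for 4-chlorophenyl also goes beyond the scatter, with a 3.4-fold higher number from compound 1 to compound 4 (0.53 log units; beyond the scatter) in the same direction, so at this stage 4-chlorophenyl stands apart from both more heavily halogenated rings. No available evidence accounts for this step.

As far as these compounds go, what stays open is whether the step belongs to chloro itself or to any group on that carbon, since a fluoro or a methoxy group there would test this. From the compounds shown here alone, the role of the remaining chloro in 4-chlorophenoxy also stays open.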